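Thioamide Analogue Gains a Second Chloro Substituent

This account rests on a few compounds, and the source may have more. Where it says the series, first, only, none or still open, it means among the compounds named here.

Measured in a functional assay on HepG2 cells (Homo sapiens) for cytotoxicity, with a stated time of 24 h; on this read-out higher numbers stand for weaker inhibition and lower numbers for stronger inhibition:
- compound 1 `COc1cc(Cl)ccc1C(=O)Nc1ccc(Cl)cc1O`: 7340 nM
- compound 2 `COc1cc(Cl)ccc1C(=O)Nc1cc(Cl)c(Cl)cc1O`: 11500 nM
- compound 3 `COc1cc(Cl)ccc1C(=S)Nc1cc(Cl)ccc1O`: 8490 nM

Compound 1 and compound 2 differ by one change, (chloro in place of hydrogen on an aromatic carbon), and the step was a 1.6-fold higher number from compound 1 to compound 2 (0.20 log units; within the scatter). Compound 3 and compound 1 share a related core, but the difference between the two cores is not broken down here; their values in this assay lie within the scatter of each other, as do those of compound 3 and compound 2.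

Compound 4 `COc1cc(Cl)ccc1C(=S)Nc1cc(Cl)c(Cl)cc1O` has not been measured. It differs from compound 3 by chloro in place of hydrogen on an aromatic carbon, the same kind of change as that from compound 1 to compound 2, though the surroundings differ: in compound 4 the new chloro group sits meta to a hydroxy group and para to a large group, whereas in compound 2 it sits meta to a large group and para to a hydroxy group.

Resting on the step from compound 1 to compound 2, a 1.6-fold higher number from compound 1 to compound 2 (0.20 log units; within the scatter), the step to compound 4 is expected to be a 1.4-fold higher number from compound 3 to compound 4 (0.15 log units; within the scatter). Compound 4 is therefore estimated at 12000 nM, with a likely range from 6000 nM to 25000 nM.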

Compound 4, half-maximal inhibitory concentration: 3160 nM
For compound 4 the middle estimate is 3.8-fold (0.58 log units) above the measured one; the measured number lies below the stated range.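

In this assay, chloro in place of hydrogen on an aromatic carbon gave a 2.7-fold lower number from compound 3 to compound 4 (0.43 log units; beyond the scatter), and the same change did not behave alike on the two cores: the same change on two cores in this assay, a 1.6-fold higher number (0.20 log units; within the scatter) from compound 1 to compound 2 and a 2.7-fold lower number (0.43 log units; beyond the scatter) from compound 3 to compound 4, 4.2-fold (0.62 log units) apart, beyond the scatter of two such steps. The step seen on the core of compound 1 therefore cannot be carried over to the core of compound 3, not even in its direction. The data do not show what lies behind this gap, and with a single pair on each core they support no general rule for either core.

As far as these compounds go, it remains open whether a fluoro, bromo or methyl group on the same carbon would follow the step on either core. From the compounds shown here alone, whether an amine there would do so also remains open.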